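The source may report more compounds than this note shows. Statements on the series, on what has been measured and on what is new or still open speak of the compounds shown alone.

Measured so far:
compound 1 `O=C(Nc1cccc(-n2cc(-c3ccncc3)c(-c3cc(O)cc(Cl)c3)n2)c1)Nc1ccc(Cl)c(C(F)(F)F)c1` gives 83% in a functional assay on NCI-H522 cells (Homo sapiens) for inhibition, read by sulforhodamine B assay, with a stated time of 48 h, tested at 0.1 uM; on this read-out lower numbers stand for a stronger effect and higher numbers for a weaker effect at the one concentration tested; compound 2 `COc1cc(Cl)cc(-c2nn(-c3cccc(NC(=O)Nc4ccc(Cl)c(C(F)(F)F)c4)c3)cc2-c2ccncc2)c1` gives 77%; compound 3 `COc1cc(Cl)cc(-c2nn(-c3cccc(NC(=O)Nc4cc(C(F)(F)F)cc(C(F)(F)F)c4)c3)cc2-c2ccncc2)c1` gives 80%.

Compound 3 stands second highest of the three numbers; its nearest neighbour is compound 1 and its furthest compound 2, both within the scatter, so the three measured compounds cannot be ordered on this read-out.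

Compound 4 `COc1cc(Cl)cc(-c2nn(-c3cccc(NC(=O)Nc4cccc(C(F)(F)F)c4)c3)cc2-c2ccncc2)c1` differs from compound 3 by hydrogen in place of trifluoromethyl on an aromatic carbon. Among the compounds with values here, the one measured step, a number 6 percentage points lower from compound 1 to compound 2 (within the scatter), concerns the oxygen on the other ring and does not bear on this change. Compound 2 and compound 3 differ on the ring where the change sits, and their values lie within the scatter of each other, which suggests that substitution on that ring has so far moved the read-out little. Nothing measured addresses removal of a trifluoromethyl group. Compound 4 is therefore expected to give a number close to that of compound 3, with a number 4 percentage points higher from compound 3 to compound 4 (within the scatter) as the expected step, within the scatter. The estimate for compound 4 is 84%, ranging from 72% to 96%.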

Compound 4, a percentage reported as activity, at one concentration (the size of the read-out at that concentration, not a potency): 53%
For compound 4 the middle estimate is 31 percentage points above the measured one, outside the stated range (below it).
By their numbers in this assay, from the lowest: compound 4; then compounds 2, 3 and 1 (each within the scatter of the next).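

In this assay, within the data shown here, the aromatic ring carrying the change proves able to move the read-out beyond the scatter, which the earlier compounds did not show: hydrogen in place of trifluoromethyl gives a number 27 percentage points lower from compound 3 to compound 4 (beyond the scatter), and hydrogen in place of chloro gives a number 24 percentage points lower from compound 2 to compound 4 (beyond the scatter). In both steps, the compound with hydrogen at the changed place has the stronger effect at the one concentration tested, so a substituent there is not neutral in this pair of comparisons. No available evidence accounts for this difference.

Still open, as far as these compounds go, is whether a methyl, a methoxy or an amine at this place would read like compound 4 or like compound 3. Also open, from the compounds shown here alone, is what happens when the remaining trifluoromethyl group of compound 4 is replaced by hydrogen.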